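Taking the carboxy group off compound 2

The compounds below may be only part of what the source reports. "The series", "measured", "known", "first", "only" and "open" are said of these compounds alone.

For the measured compounds named here, in a functional assay on the whole organism (stomach) with Rattus norvegicus as the target (a higher number here means that more compound is needed for the effect, a lower number that less compound is needed), compound 2 (`O=C(O)c1ccc(NC(=O)c2ccc(-c3nn[nH]n3)cc2)cc1`) gives 3.5 mg/kg, the lowest number of the three measured so far. Compound 1 (`O=C(O)c1ccc(NC(=O)c2ccc(C(=O)O)cc2)cc1`) gives 54.3 mg/kg, and compound 3 (`CCCCc1ccc(C(=O)Nc2cc(C(=O)O)cc(C(=O)O)c2)cc1`) gives 91.9 mg/kg. The next compound to be tested is compound 4 (`O=C(Nc1ccccc1)c1ccc(-c2nn[nH]n2)cc1`), which differs from compound 2 by one change: hydrogen in place of carboxy on an aromatic carbon. In plain terms, this puts hydrogen in place of carboxy on an aromatic carbon.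

Going by the values given here, only one measured step bears on this change: a 16-fold lower number from compound 1 to compound 2 (1.19 log units; beyond the scatter), a large step beyond the scatter, with 2H-tetrazol-5-yl in place of carboxy. That step swapped one group for another and removed nothing, so it suggests that a change at a carboxy group can matter in this series, but it does not show which way a plain removal will go. With compound 2 already lowest, a moderate rise is expected in this assay, and the estimated step is a 2.6-fold higher number from compound 2 to compound 4 (0.41 log units; beyond the scatter). For compound 4 the estimate is 9 mg/kg, with an expected range from 2 mg/kg to 40 mg/kg.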

Compound 4, dose for 50% inhibition: 40 mg/kg
For compound 4 the middle estimate is 4.4-fold (0.65 log units) below the measured one, and the stated range covers the measured number.
By their numbers in this assay, from the lowest: compound 2; then compounds 4, 1 and 3 (each within the scatter of the next, the first and the last beyond it).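

For the compounds shown here, replacing the carboxy group with hydrogen gives an 11-fold higher number from compound 2 to compound 4 (1.06 log units; beyond the scatter) in this assay and is the first plain removal in this set, since the earlier step only swapped one group for another. Compound 2 and compound 4 differ in this one place, so the carboxy group para to a large group is tied directly to the lower number of compound 2, even with the 2H-tetrazol-5-yl group kept in both. No measurement available here explains this rise. From the compounds shown here alone, whether an amine, a hydroxy group or a methyl group in place of the carboxy group would keep the number close to that of compound 2 remains open. Going by these compounds, it is also open whether removing the 2H-tetrazol-5-yl group instead, while keeping the carboxy group, would produce a step of similar size.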